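A Fluoropyridine Takes the Place of a Fluorophenyl

This account rests on a few compounds, and the source may have more. Where it says the series, first, only, none or still open, it means among the compounds named here.

In an ADME assay on CHO cells (Cricetulus griseus) for cytotoxicity, read by LDH release (a higher number here means a weaker inhibitor, a lower number a stronger inhibitor), compound 2 `CC(Oc1ccc(Cl)cc1Cl)C(=O)NCc1cccc(F)c1` gives 27000 nM and compound 3 `CC(Oc1ccc(Cl)cc1Cl)C(=O)NCc1cccc2[nH]ccc12` gives 24000 nM as its number, so these two sit level within the scatter. Compound 1 `CC(Oc1ccc(Cl)cc1Cl)C(=O)NC(c1ccc(F)cc1)C1CC1` returns only > 100000 nM as a limit of the assay and not a number. Going from compound 2 to compound 4 `CC(Oc1ccc(Cl)cc1Cl)C(=O)NCc1ccc(F)nc1` puts 6-fluoropyridin-3-yl in place of 3-fluorophenyl on a saturated chain carbon bound to an amide-type nitrogen and no measured pair shows this swap directly. Compound 2 carries a different aromatic group from compound 3 at 24000 nM yet the two match, so only a small shift is expected. The expected move a 1.5-fold higher number from compound 2 to compound 4 (0.17 log units; within the scatter) leans towards a higher number but stays within the scatter. For compound 4 the estimated value is 40000 nM (expected range 17000 nM to 90000 nM).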

Compound 4, half-maximal inhibitory concentration: > 100000 nM
Compound 4 gave a limit, no number; the forecaster's own chance of this, stated with the estimate: 15%; at least 2.5-fold (0.39 log units) between middle value and limit.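

In this assay, putting 6-fluoropyridin-3-yl in place of 3-fluorophenyl on a saturated chain carbon bound to an amide-type nitrogen gives an at least 3.7-fold higher number from compound 2 to compound 4 (0.56 log units; beyond the scatter). Within the data shown here, this is the first single-place step, and it shows that this change gives a weaker result in the assay, with a ring nitrogen as the added hetero atom. Compound 4 gives a limit and not a number, so the step's full size stays unknown: the limit of > 100000 nM in this assay, at which 2 of the 4 values shown sit.

From the compounds shown here alone, whether the ring nitrogen alone drives the shift remains open. An unsubstituted pyridin-3-yl or a 6-methoxypyridin-3-yl group would separate the part played by the nitrogen from that of the fluorine.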